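From cyano to methylcarbamoyl in a cytotoxicity series

The source may report more compounds than this note shows. Statements on the series, on what has been measured and on what is new or still open speak of the compounds shown alone.

In a functional assay on Huh-5-2 cells (Homo sapiens), read by MTT assay (on this read-out lower numbers stand for higher toxicity in this test and higher numbers for lower toxicity in this test), compound 1 (`COc1ccc(-c2ccc(Cl)cc2)c(COc2ccc(-c3nc4cc(C(=O)O)ccc4n3C3CCCCC3)cc2)c1`) gives 24000 nM and compound 2 (`N#Cc1ccc(-c2ccc(Cl)cc2)c(COc2ccc(-c3nc4cc(C(=O)O)ccc4n3C3CCCCC3)cc2)c1`) gives 23000 nM so that compound 2 stands level with compound 1 within the scatter. Compound 3 (`CNC(=O)c1ccc(-c2ccc(Cl)cc2)c(COc2ccc(-c3nc4cc(C(=O)O)ccc4n3C3CCCCC3)cc2)c1`) carries methylcarbamoyl in place of cyano on an aromatic carbon para to a 4-chlorophenyl group. Among the measured compounds shown here, the one measured step on that carbon, cyano in place of methoxy, was a 1.0-fold lower number from compound 1 to compound 2 (0.02 log units; within the scatter) and so gives no reason to expect a larger move. The expected change in this assay is a 1.2-fold higher number from compound 2 to compound 3 (0.09 log units; within the scatter) and no step beyond the scatter. Compound 3 is therefore estimated at 28000 nM (range 14000 nM to 50000 nM).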

Compound 3, half-maximal cytotoxic concentration: 25000 nM
Compound 3: middle estimate off by 1.1-fold (0.05 log units), on the high side; measured number inside the range.
By their numbers in this assay, from the lowest: compounds 2, 1 and 3 (each within the scatter of the next).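

In this assay the step from cyano to methylcarbamoyl on this aromatic carbon is a 1.1-fold higher number from compound 2 to compound 3 (0.04 log units; within the scatter) and the step from methoxy to methylcarbamoyl is a 1.0-fold higher number from compound 1 to compound 3 (0.02 log units; within the scatter) so all three groups stand level. Methylcarbamoyl brings 4 heavy atoms and 1 hydrogen-bond donor to this carbon, and the number still stays within the scatter of the other two. Nothing measured here explains this level result.

Going by these compounds, it remains open whether an amine or a longer chain on this carbon would also stay level. The same question holds for a carboxylic acid there.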